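The source may hold more compounds than are shown below. What is called first, only, known or untested is meant among the compounds shown, and "the series" means these compounds.

Measured in an ADME assay on microsomes from liver (Homo sapiens) for metabolic stability, with a stated time of 10 min; a lower number here means that less of the compound is left, a higher number that more of the compound is left:
- Compound 1 `COc1nc(C)c(Nc2nc(Cl)cn([C@H](C)C3CC3)c2=O)cc1C`: 55%
- Compound 2 `Cc1nc2c(cc1Nc1nc(Cl)cn([C@H](C)C3CC3)c1=O)COC2`: "not determined" (no result reported)
- Compound 3 `CCOc1nc(C)c(Nc2nc(Cl)cn([C@H](C)C3CC3)c2=O)cc1C`: 81%

Of the two compounds with a number, compound 3 stands highest, clearly ahead of compound 1, and compound 2 offers no comparison. The next compound, compound 4 `Cc1cc(Nc2nc(Cl)cn([C@H](C)C3CC3)c2=O)c(C)nc1N1CCCC1`, has pyrrolidin-1-yl in place of ethoxy on an aromatic carbon, next to the ring nitrogen (pyrrolidin-1-yl in place of ethoxy on an aromatic carbon).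

Within the data shown here, only one measured step bears on this change. It is a number 26 percentage points higher from compound 1 to compound 3 (beyond the scatter), a modest step that comes from methyl in place of hydrogen on a saturated chain carbon bound to an oxygen on an aromatic ring. That step enlarges the group at this place but keeps the oxygen, so it shows only loosely what a larger group might do. Among the measured compounds shown here, no measured compound has a nitrogen or a ring in this place, and the direction of the change therefore remains uncertain.

Compound 3 at 81% leaves more room on this scale for a fall than for a rise, so a modest fall is expected. The expected change is a number 15 percentage points lower from compound 3 to compound 4 (beyond the scatter). For compound 4 the estimated value is 66%, with an expected range from 40% to 90%.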

Compound 4, percent of the compound remaining: 26%
Compound 4: the middle estimate sits 40 percentage points above what was measured; the whole stated range lies above it.
By their numbers in this assay, from the lowest: compound 4; then compound 1; then compound 3.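

In this assay, among these compounds, pyrrolidin-1-yl in place of ethoxy on the aromatic carbon next to the ring nitrogen gives a number 55 percentage points lower from compound 3 to compound 4 (beyond the scatter) and is the largest step seen so far at this place; the only earlier step here was a rise, and it kept the oxygen while enlarging the group. Set against the smaller methoxy group, the same replacement gives a number 29 percentage points lower from compound 1 to compound 4 (beyond the scatter), so compound 4 lies below both ether compounds and a larger group at this place does not in itself go with more of the compound remaining. The change swaps an oxygen for a nitrogen, adds heavy atoms and brings in a five-membered ring all at once, and nothing measured here gives a reason for the fall.

The compounds shown therefore leave open which of these differences matters, since none of them separates the nitrogen from the ring. An open-chain amine such as dimethylamino or diethylamino would test the nitrogen without the ring, while a longer ether chain such as propoxy would show how far the rise seen among the ethers continues.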